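The source may hold more compounds than are shown below. What is called first, only, known or untested is meant among the compounds shown, and "the series" means these compounds.

Working notes on the series. The read-out throughout is an assay on isolated protein for inhibition of Serotonin N-acetyltransferase (Ovis aries), read by spectrophotometry, tested at 100 uM; a lower number here means less inhibition, a higher number more inhibition at the concentration tested (going by the name of the read-out). Two hydrazone analogues carry numbers: compound 1 `Cc1nnc(SCC(=O)N/N=C2\C(=O)Nc3ccc([N+](=O)[O-])cc32)s1` gives 42% and compound 3 `O=C(COc1ccc([N+](=O)[O-])cc1)N/N=C/c1ccccc1COc1ccccc1` gives 40%; these two lie within the usual scatter of each other, so no order between them is claimed. Compound 2 `O=C(O)COc1ccc(/C=N/NC(=O)c2ccc(OCc3ccccc3)cc2)cc1` returned "not determined" (no result reported), so no single number stands for it in this assay. Compound 4 `Cc1ccc(C)n1-c1ccc(C(=O)N/N=C/c2ccc(OCC(=O)O)cc2)cc1` is not yet measured. It differs from compound 2 by 2,5-dimethyl-1H-pyrrol-1-yl in place of benzyloxy on an aromatic carbon. Going by the values given here, with no measured step from compound 2 to anchor it, the expectation is a moderate effect at most, in no clear direction, probably within the scatter. Compound 4 is expected to give about 35% in this assay, plausibly between 10% and 60%.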

Compound 4, a percentage reported as inhibition, at one concentration (the size of the read-out at that concentration, not a potency): 100%
Compound 4: middle estimate off by 65 percentage points, on the low side; the whole stated range lies below it.
By their numbers in this assay, from the lowest: compounds 3 and 1 (each within the scatter of the next); then compound 4.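

No step can be read from compound 2 to compound 4, as compound 2 carries no number. The compounds shown leave open what the exchange of benzyloxy for 2,5-dimethyl-1H-pyrrol-1-yl does on its own. Nothing available bears on the result for compound 4.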